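The compounds below may be only part of what the source reports. "The series", "measured", "known", "first", "only" and "open" are said of these compounds alone.

Of the compounds shown here, two have so far been measured in a functional assay on SW480 cells (Homo sapiens) for inhibition, read by luminescence and resazurin assay, with a stated time of 3 days; on this read-out higher numbers stand for weaker inhibition and lower numbers for stronger inhibition. Compound 1 `CNc1nc(NCc2ccc(C(=O)NC3CCN(Cc4ccc(F)cc4)CC3)cc2)c2cc(C)ccc2n1` gives 1300 nM in this assay. Compound 2 `CCNc1nc(NCc2ccc(NC(=O)c3ccc(F)cc3)cc2)c2ccccc2n1` gives 2300 nM in this assay, the highest of the two numbers, although its nearest neighbour, compound 1, lies within the scatter of it; the two differ in several places at once, so their values show only that they are close. Compound 3 `CNc1nc(NCc2ccc(NC(=O)c3ccc(F)cc3)cc2)c2ccccc2n1` is not yet measured. It differs from compound 2 by a single change, (hydrogen in place of methyl on a saturated chain carbon bound to a nitrogen on an aromatic ring), that is, hydrogen in place of methyl on a saturated chain carbon bound to a nitrogen on an aromatic ring. Among the compounds with values here, no measured pair shows this change on its own, and nothing in the two measured compounds points to a large move, so the expected step from compound 2 to compound 3 is a 1.2-fold lower number from compound 2 to compound 3 (0.06 log units; within the scatter), nothing beyond the scatter in either direction. On that basis compound 3 is estimated at 2000 nM in this assay, within a range from 900 nM to 4500 nM.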

Compound 3, half-maximal inhibitory concentration: 2000 nM
For compound 3 middle estimate and measured number coincide at the digits printed, and the stated range covers the measured number.
By their numbers in this assay, from the lowest: compounds 1, 3 and 2 (each within the scatter of the next).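

Within the data shown here, compound 2 and compound 3 are the first measured pair that differs in one place only, ethylamino against methylamino, and the step between them reads a 1.2-fold lower number from compound 2 to compound 3 (0.06 log units; within the scatter) in this assay. In this pair, then, one methyl more or less at the end of this chain makes no difference that the read-out can separate from the scatter. No outside information bears on this result.

Going by these compounds, it stays open whether a longer chain such as propyl, a cyclopropyl ring or a plain amino group at this place would read the same way. On these data alone, it is equally open whether ethylamino in place of methylamino would read alike on compound 1, which carries a different side chain and a methyl on its core.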